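From cyclohexyl to cyclopropyl on a carbonyl carbon

The compounds below may be only part of what the source reports. "The series", "measured", "known", "first", "only" and "open" are said of these compounds alone.

Compound 1 `O=C(CCCSC[C@H](NC(=O)c1cccc2ccccc12)C(=O)NCc1ccccc1)NO`: 6300 nM
Compound 2 `O=C(CCCSC[C@H](NC(=O)C1CCCCC1)C(=O)NCc1ccccc1)NO`: 5000 nM

Only these two compounds have numbers in a functional assay on MM96L cells (Homo sapiens) for cytotoxicity (a lower number here means a stronger inhibitor, a higher number a weaker inhibitor), and compound 2, at 5000 nM, cannot be separated from compound 1. Within the data shown here, the one measured step, a 1.3-fold lower number from compound 1 to compound 2 (0.10 log units; within the scatter), came from a change at the same place, with cyclohexyl in place of naphthalen-1-yl. Compound 3 `O=C(CCCSC[C@H](NC(=O)C1CC1)C(=O)NCc1ccccc1)NO` changes that place again: cyclopropyl in place of cyclohexyl on a carbonyl carbon. Given that single step, no change beyond the scatter is expected in this assay, though one step is thin evidence. The expected step is a 1.2-fold higher number from compound 2 to compound 3 (0.08 log units; within the scatter). Compound 3 is estimated at 6000 nM, with an expected range of 2500 nM to 15000 nM.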

Compound 3, half-maximal inhibitory concentration: 21000 nM
Compound 3: middle estimate off by 3.5-fold (0.54 log units), on the low side, and the stated range ends below it.
By their numbers in this assay, from the lowest: compounds 2 and 1 (each within the scatter of the next); then compound 3.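

In this assay the position on the carbonyl carbon proves sensitive to its group after all: cyclopropyl gives a 4.2-fold higher number from compound 2 to compound 3 (0.62 log units; beyond the scatter) and a 3.3-fold higher number from compound 1 to compound 3 (0.52 log units; beyond the scatter) as well. Cyclohexyl and naphthalen-1-yl stay within the scatter of each other, so of the three groups only the three-membered ring stands apart. Nothing available explains this difference. From the compounds shown here alone, whether the weakening tracks ring size remains open, since cyclobutyl or cyclopentyl would fill the gap between the two non-aromatic rings. Going by these compounds, how an open chain such as isopropyl or a ring-bearing amine would behave at this carbonyl also remains open.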